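A few compounds are considered here, and "the series" means these few. Any claim that something is new, unique, unknown or untested is made for them only; others in the source may bear on it.

Measured so far:
Compound 1, `CCc1nnc(O)n2c(C(C)CC)nc(C)c12`: in a functional assay for inhibition, with Homo sapiens as the target (on this read-out lower numbers stand for stronger inhibition and higher numbers for weaker inhibition), compound 1 gives 45000 nM.
Compound 2, `CCCc1nc(C)c2c(C(C)C)cnc(Nc3cc[nH]n3)n12`: in this assay compound 2 reaches only a limit of the assay, > 48000 nM, not a number.
Compound 3, `COCc1ncc2cnnc(NCCN(C)C)n12`: in this assay compound 3 likewise reaches only a limit of the assay, > 48000 nM.

Compound 1 thus holds the only number shown in this assay; the other two values are limits, and the limit of > 48000 nM in this assay, at which 2 of the 3 values shown sit, marks where they sit. Among the measured compounds shown here, no pair of measured compounds differs in a single place, so nothing on hand ties one structural change to a change in the read-out, and the evidence for the series rests on compound 1 alone.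

Compound 4, `CCCc1nc(C)c2c(CC)nnc(O)n12`, is to be measured in this assay. It differs from compound 1 by hydrogen in place of methyl on a saturated chain carbon bound to an aromatic carbon and a saturated chain carbon. For the measured compounds named here, with no measured step to lean on, the expectation is a small step from compound 1, none beyond the scatter, in either direction. Compound 4 is therefore estimated at 50000 nM, with a range from 20000 nM to 120000 nM, which means an expected step of a 1.1-fold higher number from compound 1 to compound 4 (0.05 log units; within the scatter).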

Compound 4, half-maximal inhibitory concentration: 15600 nM
Compound 4: middle estimate off by 3.2-fold (0.51 log units), on the high side; the measured number lies below the stated range.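

In this assay, the change from sec-butyl to propyl gives a 2.9-fold lower number from compound 1 to compound 4 (0.46 log units; beyond the scatter), the first link in the series between a single structural change and the read-out. The position is therefore not silent: losing this one methyl on a saturated chain carbon bound to an aromatic carbon and a saturated chain carbon moves the number beyond the scatter, and the smaller propyl group goes with the stronger inhibition, though the step is modest. Nothing on hand gives a reason for the step.

Still open, on these data alone, is how far the read-out follows the chain at this place, as a single pair cannot show whether a plain methyl, a cyclopropyl group, a longer chain or an amine would carry the step further or reverse it. As far as these compounds go, whether the same change holds on any other core also remains untested by this pair.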